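Removal of the pyridin-4-yl group from compound 2

The compounds below may be only part of what the source reports. "The series", "measured", "known", "first", "only" and "open" are said of these compounds alone.

Measured so far:
- compound 1 `FC(F)=C(F)CCSc1nnc(S)s1`: in a functional assay on MCF7 cells (Homo sapiens) for cytotoxicity, read by MTT assay, with a stated time of 48 h (on this read-out higher numbers stand for weaker inhibition and lower numbers for stronger inhibition), compound 1 gives only the limit > 120000 nM.
- compound 2 `O=S(=O)(CCC(F)=C(F)F)c1ncc(-c2ccncc2)s1`: in this assay compound 2 gives only the limit > 120000 nM.

Among the compounds with values here, neither value is a number, so no step between measured compounds can be drawn. Compound 2 stands at the limit of > 120000 nM in this assay, at which 2 of the 2 values shown sit; nothing places it relative to compound 1 beyond that both are limits.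

Compound 3 `O=S(=O)(CCC(F)=C(F)F)c1nccs1` is the next point. It differs from compound 2 by hydrogen in place of pyridin-4-yl on an aromatic carbon, in words hydrogen in place of pyridin-4-yl on an aromatic carbon. The difluorovinyl sulfone chain and the shared core are kept.

With compound 2 known only as a limit, there is no measured shift to lean on. The expectation is a step that the limit leaves unreadable from compound 2 to compound 3, that is none beyond the scatter, with the result most likely again reported as a limit rather than a number. Compound 3 is therefore estimated at 150000 nM, with a range from 60000 nM to 400000 nM, the measurement itself still to come.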

Compound 3, half-maximal inhibitory concentration: > 120000 nM
Compound 3 gave a limit, no number (the forecaster's own chance of this, stated with the estimate: 85%); the middle value lies beyond the limit too.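

Compound 2 and compound 3 both stand only as limits, not numbers, so no step can be read between them in this assay: the limit of > 120000 nM in this assay, at which 3 of the 3 values shown sit.

The compounds shown leave open whether hydrogen in place of pyridin-4-yl shifts the read-out at all, and where any of the three compounds would fall as a number in this assay.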